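Fluoro to Bromo on an Aromatic Ring

The source may report more compounds than this note shows. Statements on the series, on what has been measured and on what is new or still open speak of the compounds shown alone.

In a functional assay on THP-1 cells (Homo sapiens) for cytotoxicity, read by MTT assay, with a stated time of 24 h (a higher number here means a weaker inhibitor, a lower number a stronger inhibitor), compound 1 (`COc1cc(/C=C2\CN(C)C/C(=C\c3ccc(Cl)cc3Cl)C2=O)cc(OC)c1`) gives 6070 nM and compound 2 (`COc1cc(/C=C2\CN(C)C/C(=C\c3ccc(C#N)cc3)C2=O)cc(OC)c1OC`) gives 820 nM while compound 3 (`CN1C/C(=C\c2ccc(F)cc2)C(=O)/C(=C/c2cccc([N+](=O)[O-])c2)C1`) gives 7160 nM in the same test. Compound 3 stands level with compound 1 within the scatter, and its number lies above that of compound 2 by more than the scatter.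

Compound 4 (`CN1C/C(=C\c2ccc(Br)cc2)C(=O)/C(=C/c2cccc([N+](=O)[O-])c2)C1`) differs from compound 3 in one place (bromo in place of fluoro on an aromatic carbon), with bromo in place of fluoro on an aromatic carbon, para to a large group. This is the change from 4-fluorophenyl to 4-bromophenyl. Among the measured compounds shown here, no measured pair of compounds isolates this kind of change, so the three values offer no direct guide to it. In this assay no step beyond the scatter is therefore expected, with at most a slight lean towards a lower number. The estimated move is a 1.3-fold lower number from compound 3 to compound 4 (0.11 log units; within the scatter) and stays within the scatter. For compound 4 the expected value is 5500 nM (2000 nM to 13000 nM).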

Compound 4, half-maximal inhibitory concentration: 7690 nM
Compound 4: the middle estimate sits 1.4-fold (0.15 log units) below what was measured; low and high end bracket the measured number.
By their numbers in this assay, from the lowest: compound 2; then compounds 1, 3 and 4 (each within the scatter of the next).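

In this assay, bromo in place of fluoro gives a 1.1-fold higher number from compound 3 to compound 4 (0.03 log units; within the scatter), and this step lies within the scatter. Among the compounds shown here, this is the first pair here that isolates a single change, and it shows that with the rest of the molecule held constant, this exchange on an aromatic carbon, para to a large group, leaves compound 3 and compound 4 level. Nothing measured here offers an account of why the two compounds stand level.

As far as these compounds go, whether an amine or a carboxylic acid in this place would also stand level with fluoro and bromo remains open. So does whether the same exchange would read alike on compounds carrying a different group elsewhere on the shared core.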